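The source may report more compounds than this note shows. Statements on the series, on what has been measured and on what is new or still open speak of the compounds shown alone.

- compound 1 `CNC(=O)[C@@H]1CCCN1S(=O)(=O)c1ccc(Cl)c(COc2cccc3c(C(F)(F)F)cc(C)nc23)c1Cl`: 1380 mL/min/kg
- compound 2 `Cc1cc(C(F)(F)F)c2cccc(OCc3c(Cl)ccc(S(=O)(=O)N4CCC[C@H]4C(N)=O)c3Cl)c2n1`: 12600 mL/min/kg
- compound 3 `Cc1cc(C(F)(F)F)c2cccc(OCc3c(Cl)ccc(S(=O)(=O)N4CCCC4)c3Cl)c2n1`: 967 mL/min/kg

In an ADME assay on microsomes (Mus musculus) for metabolic stability (a lower number here means slower removal, a higher number faster removal of the compound), compound 1 sits at the lower end of these three numbers. Its nearest step is a 1.4-fold lower number from compound 1 to compound 3 (0.15 log units; within the scatter), and its furthest is a 9.1-fold higher number from compound 1 to compound 2 (0.96 log units; beyond the scatter). Compound 4 `CNC(=O)[C@@H]1CCCN1S(=O)(=O)c1ccc(Cl)c(COc2cccc3c(-c4ccccn4)cc(C)nc23)c1Cl` differs from compound 1 as follows: pyridin-2-yl in place of trifluoromethyl on an aromatic carbon. Among the compounds with values here, no measured step touches that carbon. The steps beyond the scatter, a 9.1-fold higher number from compound 1 to compound 2 (0.96 log units; beyond the scatter) and a 13-fold lower number from compound 2 to compound 3 (1.11 log units; beyond the scatter), both concern the carbamoyl group on the saturated ring, so they bear on this change only weakly. No direction can be read from them, and no step beyond the scatter is expected. The expected step is a 1.1-fold higher number from compound 1 to compound 4 (0.04 log units; within the scatter). The estimated value for compound 4 is 1500 mL/min/kg, with an expected range of 550 mL/min/kg to 4500 mL/min/kg.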

Compound 4, clearance: 733 mL/min/kg
Beside the measured number, compound 4's estimate is 2.0-fold (0.31 log units) above it; low and high end bracket the measured number.
By their numbers in this assay, from the lowest: compounds 4, 3 and 1 (each within the scatter of the next); then compound 2.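

Within the data shown here, at the aromatic carbon opposite the ring nitrogen, the earlier compounds offered no reading; pyridin-2-yl in place of trifluoromethyl now gives a 1.9-fold lower number from compound 1 to compound 4 (0.27 log units; within the scatter) in this assay. This carbon therefore carries a six-membered aromatic ring in place of trifluoromethyl with no step beyond the scatter in this read-out. Nothing available offers an explanation for this result. Still open, as far as these compounds go, is whether phenyl or an amine at this carbon would read the same, and whether a 9.1-fold higher number from compound 1 to compound 2 (0.96 log units; beyond the scatter) recurs when pyridin-2-yl replaces trifluoromethyl.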